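Removing an Acetoxy Group from Two Related Aorta Inhibitors

The source may report more compounds than this note shows. Statements on the series, on what has been measured and on what is new or still open speak of the compounds shown alone.

Four compounds share a fused two-ring system carrying a nitrile and a pair of methyl groups. Compound 1 `CC(=O)O[C@H]1[C@H](/N=C(\NC#N)Nc2ccccc2)c2cc(C#N)ccc2OC1(C)C` bears a cyanoguanidine arm and an acetoxy group; compound 2 `CC(=O)O[C@H]1[C@H](NC(=O)Nc2ccccc2)c2cc(C#N)ccc2OC1(C)C` carries a urea arm instead. The difference between the two cores is not broken down here. Compound 3 `CC1(C)C[C@H](/N=C(\NC#N)Nc2ccccc2)c2cc(C#N)ccc2O1` is compound 1 without the acetoxy group, and compound 4 `CC1(C)C[C@H](NC(=O)Nc2ccccc2)c2cc(C#N)ccc2O1` is the corresponding partner of compound 2.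

In a functional assay (aorta) for inhibition, with Rattus norvegicus as the target (on this read-out higher numbers stand for weaker inhibition and lower numbers for stronger inhibition), compound 1 gives 2600 nM. In this assay compound 2 gives 4400 nM, and compound 3 gives 14000 nM.

The step from compound 1 to compound 3 is hydrogen in place of acetoxy on a saturated ring carbon, and it produced a 5.4-fold higher number from compound 1 to compound 3 (0.73 log units; beyond the scatter). The change planned for compound 4 is hydrogen in place of acetoxy on a saturated ring carbon, the same change at the same place on the shared core.

For compound 4 the number is expected to move upward by a 5.0-fold higher number from compound 2 to compound 4 (0.70 log units; beyond the scatter) because the same change gave a 5.4-fold higher number from compound 1 to compound 3 (0.73 log units; beyond the scatter) on the sister pair. This rests on a single measured example, so the expectation is held loosely. Compound 4 is therefore estimated at 22000 nM, with a likely range from 9000 nM to 55000 nM.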

Compound 4, half-maximal inhibitory concentration: 1800 nM
Beside the measured number, compound 4's estimate is 12-fold (1.09 log units) above it; measured number below the stated range.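

Putting hydrogen in place of acetoxy on the saturated ring carbon of the urea compound gave a 2.4-fold lower number from compound 2 to compound 4 (0.39 log units; beyond the scatter) in this assay, so the number fell here, whereas it rose for the same change on the cyanoguanidine compounds. This shows that, in this small series, the effect of removing the acetoxy group does not carry from one core to the other, in size or even in direction: the same change on two cores in this assay, a 5.4-fold higher number (0.73 log units; beyond the scatter) from compound 1 to compound 3 and a 2.4-fold lower number (0.39 log units; beyond the scatter) from compound 2 to compound 4, 13-fold (1.12 log units) apart, beyond the scatter of two such steps It does not show why the two pairs part ways, since two pairs alone cannot tell whether the cyanoguanidine and urea arms decide the outcome, and they offer no rule for predicting the change on any further core.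

The compounds shown leave open how other groups on this ring carbon, such as a hydroxyl group or an ester with a longer chain, would behave with each of the two arms. They also leave open whether a third arm, such as a thiourea or a simple amide, would follow the pattern of the urea pair, that of the cyanoguanidine pair, or neither.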